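Microsomal half-life notes: oxo-ring swap at the chain end

A few compounds are considered here, and "the series" means these few. Any claim that something is new, unique, unknown or untested is made for them only; others in the source may bear on it.

In an ADME assay on microsomes from liver (Canis lupus familiaris) for metabolic stability (a lower number here means that the compound disappears faster, a higher number that the compound lasts longer), compound 3 `Cc1cc(C(=O)Nc2ccc(Cl)cc2)ccc1N(CCN1CCCC1)C(=O)Nc1ccc(Cl)cc1` gives 2.28 h, the highest of the three numbers; compound 2 `Cc1cc(C(=O)Nc2ccc(Cl)cc2)ccc1N(CC(=O)N1CCOCC1)C(=O)Nc1ccc(Cl)cc1` gives 0.617 h and compound 1 `Cc1cc(C(=O)Nc2ccc(Cl)cc2)ccc1N(CCN1CCCC1=O)C(=O)Nc1ccc(Cl)cc1` gives 0.183 h. Compound 4 `Cc1cc(C(=O)Nc2ccc(Cl)cc2)ccc1N(CCN1CCOCC1=O)C(=O)Nc1ccc(Cl)cc1` carries 3-oxomorpholin-4-yl in place of pyrrolidin-1-yl on a saturated chain carbon, two bonds along the chain from an amide-type nitrogen. Within the data shown here, two measured steps bear on it, both ending at compound 3: a 12-fold higher number from compound 1 to compound 3 (1.10 log units; beyond the scatter) and a 3.7-fold higher number from compound 2 to compound 3 (0.57 log units; beyond the scatter). Moving away from the pyrrolidin-1-yl at this place has so far only been seen to lower the number, and in this place compound 4 most resembles compound 1. A large fall in this assay is therefore expected, roughly reversing a 12-fold higher number from compound 1 to compound 3 (1.10 log units; beyond the scatter). Compound 4 is estimated at 0.25 h, between 0.1 h and 0.7 h, which means an expected 9.1-fold lower number from compound 3 to compound 4 (0.96 log units; beyond the scatter).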

Compound 4, half-life: 0.215 h
Compound 4: the middle estimate sits 1.2-fold (0.07 log units) above what was measured; the range from low to high includes it.
By their numbers in this assay, from the lowest: compounds 1 and 4 (each within the scatter of the next); then compound 2; then compound 3.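

Replacing 2-oxopyrrolidin-1-yl with 3-oxomorpholin-4-yl at this place gives no readable shift in this assay, with a 1.2-fold higher number from compound 1 to compound 4 (0.07 log units; within the scatter), so these two oxo rings cannot be told apart here. The drop from pyrrolidin-1-yl now appears with a second oxo ring, as an 11-fold lower number from compound 3 to compound 4 (1.03 log units; beyond the scatter), and the chain bearing the oxo ring also falls short of compound 2, with a 2.9-fold lower number from compound 2 to compound 4 (0.46 log units; beyond the scatter). No measurement at hand explains these steps.

Open, going by these compounds, is whether the ring carbonyl tracks with the lower numbers. A plain morpholin-4-yl or a dimethylamino group on the same ethyl chain would test this.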